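This account rests on a few compounds, and the source may have more. Where it says the series, first, only, none or still open, it means among the compounds named here.

- Compound 1 `Oc1ccc(-c2cc(-c3cccs3)nc(-c3ccccc3Cl)c2)cc1`: 5220 nM
- Compound 2 `Oc1ccc(-c2cc(-c3cccc(Cl)c3)nc(-c3cccs3)c2)cc1`: 2720 nM
- Compound 3 `Oc1cccc(-c2cc(-c3cccc(Cl)c3)nc(-c3cccs3)c2)c1`: 3150 nM

These values come from an ADME assay on HEK293 cells (Homo sapiens) for cytotoxicity, read by CCK-8 assay and cell counting, with a stated time of 2 days; a lower number here means a stronger inhibitor, a higher number a weaker inhibitor. Compound 2 stands within the scatter of both other compounds, so the numbers do not separate it from them. Compound 4 `Oc1ccc(-c2cc(-c3ccsc3)nc(-c3cccc(Cl)c3)c2)cc1` differs from compound 2 in one place: thiophen-3-yl in place of thiophen-2-yl on an aromatic carbon, with thiophen-3-yl in place of thiophen-2-yl. Among the measured compounds shown here, no measured step changes the thiophene group, so the evidence is only indirect. Two other changes of attachment position were small: a 1.9-fold lower number from compound 1 to compound 2 (0.28 log units; within the scatter) and a 1.2-fold higher number from compound 2 to compound 3 (0.06 log units; within the scatter). On that basis, no change beyond the scatter is expected in this assay, and the expected step is a 1.1-fold higher number from compound 2 to compound 4 (0.04 log units; within the scatter). The estimate for compound 4 is 3000 nM, with an expected range of 1500 nM to 6000 nM.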

Compound 4, half-maximal inhibitory concentration: 2670 nM
Compound 4: the middle estimate sits 1.1-fold (0.05 log units) above what was measured; measured number inside the range.
By their numbers in this assay, from the lowest: compounds 4, 2, 3 and 1 (each within the scatter of the next).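

In this assay, thiophen-3-yl in place of thiophen-2-yl gives a 1.0-fold lower number from compound 2 to compound 4 (0.01 log units; within the scatter) and so adds a direct step at this position, next to the ring nitrogen, where the attachment point of the thiophene does not separate the two compounds. All three single changes of attachment position among these compounds now lie within the scatter. Nothing measured here offers an explanation for this result. The compounds shown leave open whether an amine or a longer chain at this position would give a step beyond the scatter. They also leave open what a furan or a pyridine would do in place of the thiophene.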